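Removing one methoxy from the highest of three inhibitors

The compounds below may be only part of what the source reports. "The series", "measured", "known", "first", "only" and "open" are said of these compounds alone.

Among the measured compounds shown here, in a functional assay on HCT-116 cells (Homo sapiens) for inhibition, read by sulforhodamine B assay, with a stated time of 48 h, tested at 50 uM (on this read-out higher numbers stand for more inhibition of growth at the one concentration tested and lower numbers for less inhibition of growth), compound 1 `COc1cccc(/C=C/C(=O)/C=C/c2ccc(OCc3cn(CCOc4cc(=O)oc5ccccc45)nn3)c(OC)c2)c1` gives 70% and stands highest of the three numbers measured so far. Compound 2 `COc1cc(/C=C/C(=O)/C=C/c2ccco2)ccc1OCc1cn(CCCCOc2cc(=O)oc3ccccc23)nn1` shows 47% and compound 3 `COc1ccccc1/C=C/C(=O)/C=C/c1ccc(OCc2cn(CCCCOc3cc(=O)oc4ccccc34)nn2)c(OC)c1` shows 43% so that both lie beyond the scatter under compound 1. Both differ from compound 1 in more than one place, so neither gap can be tied to a single change.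

Compound 4 `COc1cc(/C=C/C(=O)/C=C/c2ccccc2)ccc1OCc1cn(CCOc2cc(=O)oc3ccccc23)nn1` departs from compound 1 by hydrogen in place of methoxy on an aromatic carbon and this turns the 3-methoxyphenyl into phenyl, with hydrogen in place of methoxy on an aromatic carbon. For the measured compounds named here, the only measured step that exchanges a group at this kind of place on the chain is a number 4 percentage points lower from compound 2 to compound 3 (within the scatter) and it swaps furan-2-yl for 2-methoxyphenyl. Going by the values given here, no measured pair isolates the loss of a methoxy itself, so this evidence is thin, but it points to a small effect. Compound 1 at 70% tops a very short series, so a slight fall seems more likely than a rise. The estimated change is a number 7 percentage points lower from compound 1 to compound 4 (within the scatter) and it is expected to be modest. Compound 4 is expected at 63% in an estimated range from 47% to 78% on this read-out.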

Compound 4, percent growth inhibition at one concentration: 56%
The estimate for compound 4 lay 7 percentage points above the measured number; measured number inside the range.
By their numbers in this assay, from the lowest: compounds 3, 2 and 4 (each within the scatter of the next, the first and the last beyond it); then compound 1.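

In this assay, the change from 3-methoxyphenyl to phenyl gives a number 14 percentage points lower from compound 1 to compound 4 (beyond the scatter), the first step shown that isolates the loss of a methoxy on its own. Among the compounds shown here, it shows that this place, on an aromatic carbon of a six-membered aromatic ring of carbon only, is not indifferent to the change, whereas the only earlier step, a number 4 percentage points lower from compound 2 to compound 3 (within the scatter), exchanged furan-2-yl for 2-methoxyphenyl and said nothing about a methoxy alone. Nothing shown explains why hydrogen reads lower than methoxy at this place.

As far as these compounds go, it remains open whether a hydroxy group, a chlorine atom or an amine at this place would read nearer compound 1 or nearer compound 4, and so whether the methoxy itself matters or any group other than hydrogen would serve. From the compounds shown here alone, it is also open whether the step would keep its size with a longer chain on the far side of the shared core, since this single pair rests on one chain and one place on the ring.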